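A few compounds are considered here, and "the series" means these few. Any claim that something is new, unique, unknown or untested is made for them only; others in the source may bear on it.

Measured so far:
compound 1, `CCOC(=O)c1c(C)nc(NCCNc2ccnc3cc(Cl)ccc23)nc1-c1ccccc1`, with 20000 nM in an ADME assay on HeLa cells (Homo sapiens) for cytotoxicity, read by microscopy; a lower number here means that less compound is tolerated, a higher number that more compound is tolerated;
compound 2, `Cc1nc(NCCCCNc2ccnc3cc(Cl)ccc23)nc(-c2ccccc2[N+](=O)[O-])c1C(=O)OC(C)C`, with 100000 nM in this assay;
compound 3, `CCOC(=O)c1c(C)nc(NCCCCNc2ccnc3cc(Cl)ccc23)nc1-c1ccccc1`, with > 100000 nM in this assay.

Compound 3 stands at the tolerant end of the three values shown. Its result of > 100000 nM is a limit of the assay rather than a number, the one described as the limit of > 100000 nM in this assay, at which 1 of the 3 values shown sits. Compound 1 gives 20000 nM, and compound 2 gives 100000 nM; compound 1 is tolerated at a lower concentration than either of the other two. Compound 3, by contrast, is known only to its limit.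

Compound 4, `CCOC(=O)c1c(C)nc(NCCCCNc2ccnc3cc(Cl)ccc23)nc1C`, has not yet been measured. Its difference from compound 3 is methyl in place of phenyl on an aromatic carbon: a methyl in place of a phenyl on an aromatic carbon of the shared core. Among the measured compounds shown here, no measured pair in this set isolates such a change, so no measured step can be pointed to. The expectation for compound 4 in this assay is that the step of a number no higher from compound 3 to compound 4 (the limit leaves the size open) is none beyond the usual scatter, because compound 3 already reports the limit of > 100000 nM in this assay, at which 1 of the 3 values shown sits, and nothing shown suggests the methyl would bring the value down. The estimate for compound 4 is 100000 nM, between 30000 nM and 200000 nM.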

Compound 4, minimum cytotoxic concentration: >= 20000 nM
Compound 4 gave a limit, no number (the forecaster's own chance of this, stated with the estimate: 65%); the middle value is on the limit's open side.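

In this assay compound 3 gives > 100000 nM, a limit of the assay. Compound 4 gives >= 20000 nM, also a limit, so no step can be read between compound 3 and compound 4. The compounds shown leave open whether methyl in place of phenyl on an aromatic carbon changes the tolerated concentration at all.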